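Benzyl to Tert-Butyl Exchange Carried onto a Second Core

This account rests on a few compounds, and the source may have more. Where it says the series, first, only, none or still open, it means among the compounds named here.

Compound 1 `[O-]/[N+](=C\c1cn(-c2ccc(C(F)(F)F)cc2)nn1)Cc1ccccc1` and compound 3 `CC(C)(C)/[N+]([O-])=C/c1cn(-c2ccc(C(F)(F)F)cc2)nn1` share a core, and compound 3 differs from compound 1 by tert-butyl in place of benzyl on a double-bonded nitrogen. In a functional assay on THP-1 cells (Homo sapiens) for inhibition, read by ELISA, with stated times of 2 h and 48 h (on this read-out lower numbers stand for stronger inhibition and higher numbers for weaker inhibition), compound 1 gives 15400 nM, while compound 3 gives 14400 nM; the step is a 1.1-fold lower number from compound 1 to compound 3 (0.03 log units; within the scatter), so the two compounds cannot be told apart on this read-out.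

Compound 2 `[O-]/[N+](=C\c1cn(CCC(F)(F)C(F)(F)C(F)(F)C(F)(F)C(F)(F)C(F)(F)F)nn1)Cc1ccccc1` is built on a different core; the difference between the two cores is not broken down here. In this assay compound 2 gives 12100 nM, which sits within the usual scatter of both compound 1 and compound 3.

Compound 4 `CC(C)(C)/[N+]([O-])=C/c1cn(CCC(F)(F)C(F)(F)C(F)(F)C(F)(F)C(F)(F)C(F)(F)F)nn1` has not yet been measured. Compound 4 differs from compound 2 by tert-butyl in place of benzyl on a double-bonded nitrogen, the same change made from compound 1 to compound 3, at the same place. Because that earlier change produced a 1.1-fold lower number from compound 1 to compound 3 (0.03 log units; within the scatter), the step from compound 2 to compound 4 is expected to be small as well, estimated as a 1.1-fold lower number from compound 2 to compound 4 (0.04 log units; within the scatter). Compound 4 is therefore expected to give about 11000 nM in this assay, estimated to fall between 5000 nM and 25000 nM.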

Compound 4, half-maximal inhibitory concentration: 8100 nM
Estimate against measurement, compound 4: 1.4-fold (0.13 log units) above; the measured number falls inside the stated range.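

Exchanging benzyl for tert-butyl on the second core gives a 1.5-fold lower number from compound 2 to compound 4 (0.17 log units; within the scatter) in this assay, a step that stays within the scatter, as the step on the first core did. Set side by side, the two steps do not differ by more than such measurements can resolve: the same change on two cores in this assay, a 1.1-fold lower number (0.03 log units; within the scatter) from compound 1 to compound 3 and a 1.5-fold lower number (0.17 log units; within the scatter) from compound 2 to compound 4, 1.4-fold (0.15 log units) apart, within the scatter of two such steps. For these two cores, the exchange therefore carries over without a detectable difference in its size, but two pairs cannot show that it would do the same on any other core, and steps this small give no evidence that tert-butyl improves inhibition over benzyl on either core.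

The compounds shown carry only benzyl or tert-butyl on the double-bonded nitrogen, so it remains open whether a cyclohexyl group or a longer chain there would also leave the number within the scatter. On these data alone, it also remains open whether a core bearing an amine or a carboxylic acid would respond to the exchange in the same way.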